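Para substituent swap on the benzamide of compound 2

The source may report more compounds than this note shows. Statements on the series, on what has been measured and on what is new or still open speak of the compounds shown alone.

Two compounds of this series have numbers in an assay on cells for displacement of a labelled ligand from transmembrane domain-containing protein TMIGD3 (Homo sapiens), read by scintillation counting, with a stated time of 120 min (a lower number here means a stronger inhibitor, a higher number a weaker inhibitor), so far. Compound 1 `COc1ccc(C(=O)Nc2nccn3cc(-c4ccccc4)nc23)cc1` gives 162 nM. Compound 2 `Cc1ccc(C(=O)Nc2nc(-c3ccccc3)cn3cc(-c4ccccc4)nc23)cc1` gives 223 nM. Compound 2 holds the higher of the two numbers, with compound 1 nearest, but the gap between them falls within the scatter of repeated measurements, so no order between the two can be read from them. For the measured compounds named here, no pair of measured compounds differs in a single place, so no measured single step is available for the series.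

Compound 3 `O=C(Nc1nc(-c2ccccc2)cn2cc(-c3ccccc3)nc12)c1ccc(F)cc1` remains to be measured in this assay. It differs from compound 2 by fluoro in place of methyl on an aromatic carbon. Going by the values given here, nothing among the measured compounds shows this exchange, so the direction and size of the step can only be guessed. The step from compound 2 is expected to be small, with no clear direction, and to stay within the scatter. Compound 3 is therefore estimated at 250 nM, with a range from 110 nM to 560 nM. The estimated step is a 1.1-fold higher number from compound 2 to compound 3 (0.05 log units; within the scatter).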

Compound 3, inhibition constant: 38 nM
For compound 3 the middle estimate is 6.6-fold (0.82 log units) above the measured one; measured number outside the range, below it.
By their numbers in this assay, from the lowest: compound 3; then compounds 1 and 2 (each within the scatter of the next).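

In this assay, for the compounds shown here, the exchange of 4-methylphenyl for 4-fluorophenyl provides the first measured single step: a 5.9-fold lower number from compound 2 to compound 3 (0.77 log units; beyond the scatter). This shows that the aromatic carbon para to a large group responds to a change of substituent, even when one heavy atom replaces one heavy atom and neither group carries a hydrogen-bond donor, a hydrogen-bond acceptor or a net charge. No measurement here bears on the reason for the size or direction of this step.

This single exchange does not show how the position would read with other groups, such as chloro, a nitrile or an amine, or with no substituent at all. Going by these compounds, compound 1 differs from compound 2 and from compound 3 in more than one place, so it cannot be read as a step from either, and whether the fluoro for methyl step would carry over to the core of compound 1 remains open.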